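Replacing a silicon-bearing chain with a bulkier all-carbon chain

The source may hold more compounds than are shown below. What is called first, only, known or untested is meant among the compounds shown, and "the series" means these compounds.

Compound 1 `CCCC(C)Nc1oc2c(C)ncc(CO)c2c1Nc1ccccn1`: 9010 nM
Compound 2 `Cc1ncc(CO)c2c(Nc3ccccn3)c(N)oc12`: "not active" (no number reported)
Compound 3 `Cc1ncc(CO)c2c(Nc3ccccn3)c(NC[Si](C)(C)C)oc12`: 4990 nM

In a functional assay on HEK293 cells for agonist activity at Toll-like receptor 8 (Homo sapiens), read by reporter gene assay (a lower number here means that less compound is needed, a higher number that more compound is needed for the effect), compound 3 gives 4990 nM and has the lowest of the two numbers; compound 1 is nearest, and the step of a 1.8-fold lower number from compound 1 to compound 3 (0.26 log units; within the scatter) is within the scatter. Compound 2 has no number here, only the entry that it is not active. Compound 4 `Cc1ncc(CO)c2c(Nc3ccccn3)c(NC(C)(C)CC(C)(C)C)oc12` differs from compound 3 in one place: a group of 8 heavy atoms (8 carbon; no ring) in place of a group of 5 heavy atoms (4 carbon, 1 silicon; no ring), on a nitrogen on an aromatic ring. Among the measured compounds shown here, the only step that bears on this change is a 1.8-fold lower number from compound 1 to compound 3 (0.26 log units; within the scatter), where exchanging one chain of similar size for another at this nitrogen moved the number hardly at all. A further chain exchange is therefore expected to stay within the scatter, with no direction implied. Compound 4 is estimated at 5500 nM (range 1800 nM to 17000 nM), an expected step of a 1.1-fold higher number from compound 3 to compound 4 (0.04 log units; within the scatter).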

Compound 4, half-maximal effective concentration: "not active" (no number reported)
Compound 4 has no reported number here, and the estimate cannot be compared.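

Among the compounds shown here, compound 4, like compound 2, is entered as not active in this assay and has no number, so no step from compound 3 to compound 4 can be read. Nothing measured here bears on this result. Which chains on this nitrogen give a measurable effect remains open.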